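Branching the ketone chain: from propyl to isopropyl

A few compounds are considered here, and "the series" means these few. Any claim that something is new, unique, unknown or untested is made for them only; others in the source may bear on it.

Measured so far in an assay on HEK293 cells for positive allosteric modulation of metabotropic glutamate receptor 2 (Rattus norvegicus), read by thallium flux, with a stated time of 2.5 min; on this read-out higher numbers stand for larger maximal responses and lower numbers for smaller maximal responses:
compound 1 `COc1cc(C(=O)O)ccc1OCCCCOc1ccc(C(=O)C(C)C)c(O)c1C` gives 73.1%
compound 2 `Cc1cc(C(=O)O)ccc1OCCCCOc1ccc(C(=O)CC(C)C)c(O)c1C` gives 83.9%
compound 3 `CCCC(=O)c1ccc(OCCCCOc2ccc(C(=O)O)cc2C)c(C)c1O` gives 79.3%

Compound 3 sits between the other two, and all three lie within the scatter of one another, so no order among them can be read. Going by the values given here, the only measured step, a number 4.6 percentage points lower from compound 2 to compound 3 (within the scatter), changes a chain that branches and stays within the scatter. Compound 4 `Cc1cc(C(=O)O)ccc1OCCCCOc1ccc(C(=O)C(C)C)c(O)c1C` differs from compound 3 in the same region: isopropyl in place of propyl on a carbonyl carbon. Compound 1 also carries the isopropyl ketone and gives a value within the scatter of compound 3, which supports expecting no change beyond the scatter. The expected step of a number 1.3 percentage points lower from compound 3 to compound 4 (within the scatter) is therefore small, and compound 4 is estimated at 78%, between 66% and 90%.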

Compound 4, largest response reached (reported as percent of maximum), in percent of the reference or control that the assay uses: 76.9%
The estimate for compound 4 lay 1.1 percentage points above the measured number; low and high end bracket the measured number.
By their numbers in this assay, from the lowest: compounds 1, 4, 3 and 2 (each within the scatter of the next, the first and the last beyond it).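

In this assay isopropyl in place of propyl on a carbonyl carbon gives a number 2.4 percentage points lower from compound 3 to compound 4 (within the scatter) and isopropyl in place of isobutyl gives a number 7 percentage points lower from compound 2 to compound 4 (within the scatter) so these three chains cannot be told apart at this position. Methyl in place of methoxy on an aromatic carbon gives a number 3.8 percentage points higher from compound 1 to compound 4 (within the scatter) and so cannot be told apart from no change either. Nothing available explains these small steps.

Still open, as far as these compounds go, is whether a cyclopropyl group or a longer chain such as hexyl on the carbonyl carbon would move the response beyond the scatter.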